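This account rests on a few compounds, and the source may have more. Where it says the series, first, only, none or still open, it means among the compounds named here.

Compound 3 `Cn1cnc(-c2nc(N)c3cc(Cc4ccccc4)sc3n2)c1` gives 2330 nM in a functional assay on CHO-K1 cells for antagonist activity at adenosine receptor A1 (Homo sapiens), read by a beta-galactosidase reporter and cAMP accumulation, with stated times of 15 min and 6 h (a higher number here means a weaker inhibitor, a lower number a stronger inhibitor), the highest of the two numbers shown. Compound 1 `Cc1ccc(-c2nc(N)c3cc(Cc4ccccc4Cl)sc3n2)o1` gives 26.1 nM. Compound 2 `Cc1ccc(-c2nc(N)c3cc(Cc4ccccc4F)sc3n2)o1` reaches only the limit of the assay, < 16 nM; this is the limit of < 16 nM in this assay, at which 1 of the 3 values shown sits. Among the measured compounds shown here, the one measured step, an at least 1.6-fold lower number from compound 1 to compound 2 (0.21 log units; that floor lies within the scatter), stays within the scatter. Compound 4 `Nc1nc(-c2cccc(Cl)n2)nc2sc(Cc3ccccc3)cc12` differs from compound 3 in a single spot: 6-chloropyridin-2-yl in place of 1-methyl-1H-imidazol-4-yl on an aromatic carbon. For the measured compounds named here, no measured step covers this exchange, so the expectation rests on the wide gap between compound 3 and compound 1. Compound 4 is expected to reach 60 nM, with the range 10 nM to 400 nM, meaning an estimated 39-fold lower number from compound 3 to compound 4 (1.59 log units; beyond the scatter).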

Compound 4, inhibition constant: > 1000 nM
Compound 4 was reported as a limit; the forecaster's own chance of this, stated with the estimate: 15%; middle value at least 16-fold (1.22 log units) away from the limit.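

The step from compound 3 to compound 4 cannot be read: compound 4 gives only a limit of the assay, > 1000 nM. On these data alone, whether 6-chloropyridin-2-yl or 1-methyl-1H-imidazol-4-yl gives the lower number in this assay stays open.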